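This account rests on a few compounds, and the source may have more. Where it says the series, first, only, none or still open, it means among the compounds named here.

In a functional assay on MCF7 cells (Homo sapiens) for cytotoxicity, read by MTT assay, with a stated time of 72 h (on this read-out lower numbers stand for stronger inhibition and higher numbers for weaker inhibition), compound 1 `COc1cccc(/C=C2\CCC/C(=C\c3cccc(O)c3)C2=O)c1OC` gives 8800 nM and compound 2 `COc1ccc(/C=C2\CCC/C(=C\c3cccc(Br)c3)C2=O)cc1OC` gives 5300 nM. For the measured compounds named here, these two values lie within the usual scatter of each other, so compound 2 cannot be separated from compound 1 on the only numbers available. Compound 3 `COc1ccc(/C=C2\CCC/C(=C\c3ccc(O)cc3)C2=O)cc1OC` differs from compound 2 in one place: 4-hydroxyphenyl in place of 3-bromophenyl on a double-bonded chain carbon bound to a double-bonded ring carbon. No measured pair in this assay isolates this change, so its size has not been shown directly. Going by the values given here, the only hint is that compound 1, which also carries a hydroxyphenyl group, gives 8800 nM. On that basis, no step beyond the scatter is expected in either direction, and the estimated step is small: a 1.3-fold higher number from compound 2 to compound 3 (0.12 log units; within the scatter). The expected value for compound 3 is 7000 nM, with an estimated range of 2500 nM to 20000 nM.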

Compound 3, half-maximal inhibitory concentration: 17000 nM
For compound 3 the middle estimate is 2.4-fold (0.39 log units) below the measured one, and the stated range covers the measured number.
By their numbers in this assay, from the lowest: compounds 2, 1 and 3 (each within the scatter of the next, the first and the last beyond it).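

In this assay, for the compounds shown here, replacing 3-bromophenyl with 4-hydroxyphenyl on a double-bonded chain carbon bound to a double-bonded ring carbon gives a 3.2-fold higher number from compound 2 to compound 3 (0.51 log units; beyond the scatter) and is the first single change here with a step beyond the scatter. The result shows that this position is sensitive to the group it carries, at least for this exchange, and that the exchange weakens inhibition to a modest degree. No measured evidence on these groups is available to explain the step.

The change alters both the substituent and where it sits on the phenyl ring, and the compounds shown do not separate these two parts. From the compounds shown here alone, whether 4-bromophenyl or 4-aminophenyl on the core of compound 2 would stay close to compound 2 or to compound 3 remains open.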